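The source may hold more compounds than are shown below. What is called first, only, known or untested is meant among the compounds shown, and "the series" means these compounds.

Working notes on the hydrazone series. The shared core carries a substituted phenyl on the hydrazone nitrogen, and three variants of that phenyl have been run in a functional assay on the whole organism for inhibition, with Rattus norvegicus as the target; a higher number here means that more compound is needed for the effect, a lower number that less compound is needed. Compound 1 `CC1CC/C(=N\Nc2ccc(F)cc2)c2ncc(C(=O)O)c(=O)n21` carries fluoro and in this assay gives 12.2 umol/kg. Compound 2 `COc1ccc(N/N=C2\CCC(C)n3c2ncc(C(=O)O)c3=O)cc1` carries methoxy and gives 0.8 umol/kg. Compound 3 `Cc1ccc(N/N=C2\CCC(C)n3c2ncc(C(=O)O)c3=O)cc1` carries methyl and gives 1.3 umol/kg. Compound 3 thus stands second highest of the three numbers, close to compound 2 and well apart from compound 1: the step of a 1.6-fold higher number from compound 2 to compound 3 (0.21 log units; within the scatter) is within the scatter, whereas a 9.4-fold lower number from compound 1 to compound 3 (0.97 log units; beyond the scatter) and a 15-fold lower number from compound 1 to compound 2 (1.18 log units; beyond the scatter) are both beyond it.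

The next compound, compound 4 `CC1CC/C(=N\Nc2ccc([N+](=O)[O-])cc2)c2ncc(C(=O)O)c(=O)n21`, differs from compound 3 by nitro in place of methyl on an aromatic carbon. Among the measured compounds shown here, two measured steps bear on a swap at this position. Methoxy in place of fluoro gave a 15-fold lower number from compound 1 to compound 2 (1.18 log units; beyond the scatter), and methyl in place of fluoro gave a 9.4-fold lower number from compound 1 to compound 3 (0.97 log units; beyond the scatter); methyl against methoxy, a 1.6-fold higher number from compound 2 to compound 3 (0.21 log units; within the scatter), changed nothing beyond the scatter. For the measured compounds named here, no nitro has been run here, so the direction for compound 4 rests on the fact that fluoro, the one group unlike methyl and methoxy, gave the highest number. A step upward beyond the scatter is therefore expected for compound 4, with a step of a 3.8-fold higher number from compound 3 to compound 4 (0.59 log units; beyond the scatter). The estimate for compound 4 in this assay is 5 umol/kg, with a range from 1.3 umol/kg to 20 umol/kg.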

Compound 4, dose for 50% inhibition: 0.8 umol/kg
Estimate against measurement, compound 4: 6.3-fold (0.80 log units) above, outside the stated range (below it).
By their numbers in this assay, from the lowest: compounds 2, 4 and 3 (each within the scatter of the next); then compound 1.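

In this assay the swap of nitro for methyl gives a 1.6-fold lower number from compound 3 to compound 4 (0.21 log units; within the scatter) and so stays inside the scatter, the swap of nitro for methoxy gives no change at the digits printed from compound 2 to compound 4 (within the scatter) and does the same, and the swap of nitro for fluoro gives a 15-fold lower number from compound 1 to compound 4 (1.18 log units; beyond the scatter) and lies well beyond it. At this aromatic carbon, para to a large group, the series therefore falls into two sets: nitro, methyl and methoxy together, and fluoro alone, with none of the four compounds going against that split, and a change from methyl to nitro, which adds heavy atoms and hydrogen-bond acceptors, moves the number by no more than the scatter. No measurement at hand accounts for why fluoro stands apart from the other three groups.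

Going by these compounds, the separation rests on one fluoro compound, so it remains open whether chloro or bromo would sit with fluoro or with the other three groups. On these data alone, it is equally open whether an amine, a carboxylic acid or a longer chain such as butyl at this carbon would stay with nitro, methyl and methoxy.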